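Swapping the amide substituent on a fluorinated enamide series

The compounds below may be only part of what the source reports. "The series", "measured", "known", "first", "only" and "open" are said of these compounds alone.

Compound 1 `CN(C)C(=O)/C=C1\CCc2ccc(F)cc21` is the point of departure. Going by the values given here, in a functional assay on the whole organism with Mus musculus as the target, at a dose of 100 mg/kg by the intraperitoneal route (a lower number here means less inhibition, a higher number more inhibition at the dose given (going by the name of the read-out)), compound 1 gives 100%, and compound 3 `CN(C)C(=O)/C=C1\CCc2c(F)cc(F)cc21` gives 100%, the two standing level at the top of the three numbers; the only single-place step, no change at the digits printed from compound 1 to compound 3 (within the scatter), changes nothing beyond the scatter. Among the compounds with values here, compound 2 `O=C(/C=C1\CCc2cc(Cl)ccc21)NC1CC1` gives 17%, far below compound 1, but it differs from compound 1 in two places, so no single step can be drawn from it.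

Compound 4 `O=C(/C=C1\CCc2ccc(F)cc21)NCCO` is the untested member. It differs from compound 1 in one place: (2-hydroxyethyl)amino in place of dimethylamino on a carbonyl carbon. Within the data shown here, no measured step touches the carbonyl substituent, so the weak result of compound 2, which also carries a different amino group on the carbonyl, is the only hint, and it is confounded by its second change. A drop is therefore expected for compound 4, though with wide uncertainty; the expected step is a number 55 percentage points lower from compound 1 to compound 4 (beyond the scatter). The estimate for compound 4 is 45%, with a range from 10% to 90%.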

Compound 4, a percentage reported as inhibition, in the whole organism at one dose (the size of the read-out at that dose, not a potency): 50%
Beside the measured number, compound 4's estimate is 5 percentage points below it, within the range that was stated.
By their numbers in this assay, from the lowest: compound 2; then compound 4; then compounds 1 and 3 (each within the scatter of the next).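

Going by these compounds alone, the step at the carbonyl carbon shows that this position matters in this assay: (2-hydroxyethyl)amino in place of dimethylamino gives a number 50 percentage points lower from compound 1 to compound 4 (beyond the scatter), whereas the only earlier single-place step, on an aromatic carbon, gave no change at the digits printed from compound 1 to compound 3 (within the scatter). The change weakens the read-out without removing it, as compound 4 still gives 50%, and this clean comparison is free of the second change that confounds compound 2. Nothing available explains the size of this step.

From the compounds shown here alone, what stays open is which part of the exchange carries the drop, a question that an ethylamino group on the same carbonyl carbon, lacking the oxygen, would help to settle. Also open, going by these compounds, is how a longer chain such as 3-hydroxypropylamino, or a cyclic amine such as morpholine, would read out at this position.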